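Removing a Hydroxy Group from a Soluble Compound

The source may report more compounds than this note shows. Statements on the series, on what has been measured and on what is new or still open speak of the compounds shown alone.

Values in a physicochemical assay for solubility, in phosphate buffer, with a stated time of 24 h, at pH 7.4, tested at 200 uM (on this read-out lower numbers stand for lower solubility and higher numbers for higher solubility), follow, and those that carry a sign are limits of the assay, not numbers.

- Compound 1 `O=C(c1ccc(F)c(O)c1)c1ccc2cc(O)ccc2n1` gives > 200000 nM as a limit
- Compound 2 `CN(c1ccc(F)c(O)c1)c1cccc(-c2cccc(O)c2F)n1` gives > 200000 nM as a limit
- Compound 3 `O=C(c1ccc(F)c(O)c1)c1ccc2ccccc2c1` gives 25000 nM as a number

Compound 1 stands at the limit of > 200000 nM in this assay, at which 2 of the 3 values shown sit, and so has a limit rather than a number. Compound 4 `O=C(c1ccc(F)c(O)c1)c1ccc2ccccc2n1` keeps the core of compound 1 but carries hydrogen in place of hydroxy on an aromatic carbon, on a six-membered aromatic ring of carbon only that is part of a fused or bridged system of two rings (hydrogen in place of hydroxy on an aromatic carbon). Within the data shown here, no pair of measured compounds shows this change alone, so the guide is indirect. Compound 3 also has hydrogen there, although its core is not the same as that of compound 4, and in this assay compound 3 gives 25000 nM as a true number. On that single comparison a downward step is expected, with an at least 2.5-fold lower number from compound 1 to compound 4 (0.39 log units; beyond the scatter) as its estimated size and a reading at the limit still possible. For compound 4 the expected value is 80000 nM with an estimated range from 25000 nM to 200000 nM in repeat measurements.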

Compound 4, solubility: > 200000 nM
Compound 4: a limit, no number (the forecaster's own chance of this, stated with the estimate: 25%); middle value at least 2.5-fold (0.39 log units) from the limit.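

Compound 1 and compound 4 both give limits rather than numbers, so no step between them can be read, and the change from hydroxy to hydrogen has no measurable size here: the limit of > 200000 nM in this assay, at which 3 of the 4 values shown sit.

The compounds shown leave open whether hydrogen in place of hydroxy on an aromatic carbon changes the solubility read-out on the core of compound 1 at all, and by how much.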